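Adding a chloro group to compound 3

This account rests on a few compounds, and the source may have more. Where it says the series, first, only, none or still open, it means among the compounds named here.

Values in a functional assay on MOLT-4 cells (Homo sapiens) for antiproliferative activity, with a stated time of 48 h; on this read-out higher numbers stand for weaker inhibition and lower numbers for stronger inhibition:
- compound 1 `C=C(Br)C(=O)Nc1ccc(/C=C/C(=O)c2ccccc2)cc1` gives 3100 nM
- compound 2 `C=C(Br)C(=O)Nc1ccc(/C=C/C(=O)c2ccc(Cl)cc2)cc1` gives 810 nM
- compound 3 `Nc1ccc(/C=C/C(=O)c2ccccc2)cc1` gives 10000 nM
- compound 4 `Nc1ccc(/C=C/C(=O)c2ccc(Cl)cc2)cc1` has no value yet

Among the compounds with values here, compound 3 has the highest number of the three measured compounds, which makes it the weakest inhibitor in this assay so far. Compound 4 differs from it by a single change (chloro in place of hydrogen on an aromatic carbon): chloro in place of hydrogen on an aromatic carbon, para to a large group.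

The same swap has been measured once, and it gave a 3.8-fold lower number from compound 1 to compound 2 (0.58 log units; beyond the scatter) as a modest gain. The other measured step, a 3.2-fold higher number from compound 1 to compound 3 (0.51 log units; beyond the scatter), involves a different change, hydrogen in place of (1-bromoethenyl)carbonyl on a nitrogen. One example is thin evidence, and that swap was made on a compound carrying the (1-bromoethenyl)carbonyl group, which compound 3 lacks. Even so, a modest move towards a lower number is the reasonable expectation, so the expected change is a 3.6-fold lower number from compound 3 to compound 4 (0.55 log units; beyond the scatter) in this test. Compound 4 is estimated at 2800 nM with an expected range of 1000 nM to 8000 nM in this assay here.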

Compound 4, half-maximal inhibitory concentration: 7800 nM
Beside the measured number, compound 4's estimate is 2.8-fold (0.44 log units) below it, and the stated range covers the measured number.
By their numbers in this assay, from the lowest: compound 2; then compound 1; then compounds 4 and 3 (each within the scatter of the next).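

In this assay chloro in place of hydrogen on an aromatic carbon, para to a large group, gives a 1.3-fold lower number from compound 3 to compound 4 (0.11 log units; within the scatter) and so no change can be read on the core that lacks the (1-bromoethenyl)carbonyl group. The gain seen earlier therefore does not carry over from one core to the other: the same change on two cores in this assay, a 3.8-fold lower number (0.58 log units; beyond the scatter) from compound 1 to compound 2 and a 1.3-fold lower number (0.11 log units; within the scatter) from compound 3 to compound 4, 3.0-fold (0.47 log units) apart, beyond the scatter of two such steps. Seen from the nitrogen, the loss on replacing the (1-bromoethenyl)carbonyl group with hydrogen is larger when the chloro group is present, at a 9.6-fold higher number from compound 2 to compound 4 (0.98 log units; beyond the scatter) and so the two changes do not simply add up: the same change on two cores in this assay, a 3.2-fold higher number (0.51 log units; beyond the scatter) from compound 1 to compound 3 and a 9.6-fold higher number (0.98 log units; beyond the scatter) from compound 2 to compound 4, 3.0-fold (0.47 log units) apart, beyond the scatter of two such steps.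

The compounds shown leave open whether another group at this position, such as fluoro, methoxy or a carboxylic acid, would behave like chloro. They also leave open whether a plain acetyl group on the nitrogen would support the same gain from chloro.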